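Trimethoxystyryl ketones on SW982 cells: a methoxyphenyl variant

This account rests on a few compounds, and the source may have more. Where it says the series, first, only, none or still open, it means among the compounds named here.

Of the compounds shown here, three sharing one core have been tested in a functional assay on SW982 cells (Homo sapiens) for inhibition, read by MTT assay, with a stated time of 72 h; a lower number here means a stronger inhibitor, a higher number a weaker inhibitor. Compound 1 `COc1cc(OC)c(OC)cc1/C=C/C(=O)c1ccc([N+](=O)[O-])cc1` gives > 150000 nM, a limit of the assay rather than a number. Compound 2 `COc1cc(OC)c(OC)cc1/C=C/C(=O)c1ccc(-c2c[nH]cn2)cc1` likewise gives a limit, > 150000 nM. The step that the two limits leave unreadable from compound 1 to compound 2 therefore cannot be read. Compound 3 `COc1cc(OC)c(OC)cc1/C=C/C(=O)c1cc(O)ccc1O` also gives only a limit, > 150000 nM. All three values sit at the limit of > 150000 nM in this assay, at which 3 of the 3 values shown sit. Compound 4 `COc1ccc(C(=O)/C=C/c2cc(OC)c(OC)cc2OC)cc1` differs from compound 3 by 4-methoxyphenyl in place of 2,5-dihydroxyphenyl on a carbonyl carbon. Among the compounds with values here, no measured step bears on this change, and the single step present is unreadable. The expected step is an at least 1.2-fold lower number from compound 3 to compound 4 (0.09 log units; that floor lies within the scatter), with no direction beyond the scatter readable. Compound 4 is estimated to give 120000 nM, between 30000 nM and 400000 nM, and is expected most likely to be reported again only as a limit.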

Compound 4, half-maximal inhibitory concentration: 60500 nM
Compound 4: the middle estimate sits 2.0-fold (0.30 log units) above what was measured; the range from low to high includes it.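

Within the data shown here, compound 4 is the only one of the four compounds that gives a number rather than a limit in this assay, so changing the group on the carbonyl carbon can move the value into the measurable range. Three changes now read as steps: 4-methoxyphenyl in place of 2,5-dihydroxyphenyl gives an at least 2.4-fold lower number from compound 3 to compound 4 (0.39 log units; beyond the scatter), methoxy in place of 1H-imidazol-4-yl gives an at least 2.4-fold lower number from compound 2 to compound 4 (0.39 log units; beyond the scatter), and methoxy in place of nitro gives an at least 2.4-fold lower number from compound 1 to compound 4 (0.39 log units; beyond the scatter). Each step is only a floor, since the starting value of each is a limit: the limit of > 150000 nM in this assay, at which 3 of the 4 values shown sit.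

From the compounds shown here alone, the true size of these steps remains open. So does whether an amine or a carboxylic acid in place of the methoxy group would give a lower number than compound 4.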